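Series notes: single-point CDK8 inhibition, outlook for compound 3

The source may report more compounds than this note shows. Statements on the series, on what has been measured and on what is new or still open speak of the compounds shown alone.

compound 1 `NC(=O)/C=C/c1ccncc1-c1ccc2ccccc2c1`: 102%
compound 2 `O=C(/C=C/c1ccncc1-c1ccc2ccccc2c1)NC1CC1`: 102%

In an assay on a protein complex for inhibition of CDK8/Cyclin C (Homo sapiens), with a stated time of 1 h, tested at 10 uM (on this read-out higher numbers stand for more inhibition at the one concentration tested (going by the name of the read-out) and lower numbers for less inhibition), compound 1 gives 102% and compound 2 gives 102%. For the measured compounds named here, the one measured step, no change at the digits printed from compound 1 to compound 2 (within the scatter), places compound 2 level with compound 1. Compound 3 `COC(=O)CCc1ccncc1-c1ccc2ccccc2c1` differs from compound 2 by 2-(methoxycarbonyl)ethyl in place of 2-(cyclopropylcarbamoyl)ethenyl on an aromatic carbon. Going by the values given here, that measured step touched only the amide-type nitrogen, so no measured step bears directly on this larger change; the expectation rests on the numbers of compound 1 and compound 2 in this assay being level with each other. A downward step a number 47 percentage points lower from compound 2 to compound 3 (beyond the scatter) is expected, with wide uncertainty. Compound 3 is estimated at 55%, range 15% to 95%.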

Compound 3, a percentage reported as inhibition, at one concentration (the size of the read-out at that concentration, not a potency): 98%
The estimate for compound 3 lay 43 percentage points below the measured number, outside the stated range (above it).
By their numbers in this assay, from the lowest: compounds 3, 1 and 2 (each within the scatter of the next).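

In this assay, the position opposite the ring nitrogen takes a far larger change than the earlier amide-nitrogen step: 2-(methoxycarbonyl)ethyl in place of the 2-(cyclopropylcarbamoyl)ethenyl group gives a number 4 percentage points lower from compound 2 to compound 3 (within the scatter), and in place of 2-carbamoylethenyl gives a number 4 percentage points lower from compound 1 to compound 3 (within the scatter). At this single concentration, the read-out therefore does not separate the ester chain from either ethenyl amide, even though the ester has no hydrogen-bond donor. Nothing available explains this result.

Single-concentration values leave any potency differences among the three compounds open. Also open, on these data alone, is whether a carboxylic acid, an amine or a longer chain at this position would give a similar read-out.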